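Phenyl in place of thiophen-3-yl on the shared core

This account rests on a few compounds, and the source may have more. Where it says the series, first, only, none or still open, it means among the compounds named here.

Compound 1 (`COc1ncnc2c1c(-c1ccccc1)cn2[C@@H]1O[C@H](CO)[C@@H](O)[C@H]1O`) and compound 2 (`CNc1ncnc2c1c(-c1ccsc1)cn2[C@@H]1O[C@H](CO)[C@@H](O)[C@H]1O`) share a core. In a functional assay on A549 cells (Homo sapiens), read by MTT assay, with a stated time of 72 h (a lower number here means a stronger inhibitor, a higher number a weaker inhibitor), compound 1 gives > 20000 nM as a limit of the assay. Compound 2 gives > 20000 nM as a limit too, and that limit is all that shows where it stands. Compound 3 (`CNc1ncnc2c1c(-c1ccccc1)cn2[C@@H]1O[C@H](CO)[C@@H](O)[C@H]1O`) has phenyl in place of thiophen-3-yl on an aromatic carbon. In this assay the expected step of a number no higher from compound 2 to compound 3 (the limit leaves the size open) is estimated to lie within the scatter, with no direction expected. Compound 1 and compound 2 give the only basis for this expectation (the limit of > 20000 nM in this assay, at which 2 of the 2 values shown sit). For compound 3 the estimated value is 20000 nM with an expected range (7000 nM to 40000 nM).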

Compound 3, half-maximal inhibitory concentration: > 20000 nM
Compound 3: no number, only a limit; the forecaster's own chance of this, stated with the estimate: 80%; the middle value sits exactly at the limit.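

In this assay, within the data shown here, compound 3 gives > 20000 nM, a limit of the assay, so no step from compound 1 or compound 2 to compound 3 can be read. The compounds shown leave open whether either change on the shared core alters activity in this assay.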